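The compounds below may be only part of what the source reports. "The series", "measured", "known", "first", "only" and "open" are said of these compounds alone.

In a functional assay on the whole organism with Rattus norvegicus as the target, at a dose of 20 mg/kg by the intraperitoneal route (on this read-out higher numbers stand for more inhibition at the one dose given (going by the name of the read-out) and lower numbers for less inhibition), the measured compounds stand as follows:

compound 1, `Nc1nc(N)nc(-c2cccc(F)c2)n1`: 70%
compound 2, `Nc1nc(N)nc(-c2cccc(C(F)(F)F)c2)n1`: 81%
compound 3, `Nc1nc(N)nc(-c2cccc(Cl)c2)n1`: 100%

Compound 3 stands highest of the three, its nearest neighbour being compound 2 and the furthest compound 1. The two steps that lead into compound 3 both involve chloro entering on the aromatic carbon: a number 30 percentage points higher from compound 1 to compound 3 (beyond the scatter) and a number 19 percentage points higher from compound 2 to compound 3 (beyond the scatter). The third measured step, a number 11 percentage points higher from compound 1 to compound 2 (beyond the scatter), shows that the larger trifluoromethyl also sits above fluoro. Compound 4, `CSc1cccc(-c2nc(N)nc(N)n2)c1`, differs from compound 3 by methylsulfanyl in place of chloro on an aromatic carbon. Among the measured compounds shown here, no measured step involves methylsulfanyl, so the direction is inferred only from the fact that every step toward chloro was a rise; leaving chloro is therefore expected to cost something, most likely a modest fall in this assay, though possibly no more than the scatter. Compound 4 is expected to give 78%, with a range from 55% to 100%. This estimate would mean a step of a number 22 percentage points lower from compound 3 to compound 4 (beyond the scatter).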

Compound 4, a percentage reported as inhibition, in the whole organism at one dose (the size of the read-out at that dose, not a potency): 49%
Compound 4: middle estimate off by 29 percentage points, on the high side, outside the stated range (below it).
By their numbers in this assay, from the lowest: compound 4; then compound 1; then compound 2; then compound 3.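

In this assay, among the compounds shown here, methylsulfanyl is the first group at this aromatic carbon to give a number under that of fluoro, with a number 21 percentage points lower from compound 1 to compound 4 (beyond the scatter), so the position can lose as well as gain relative to the fluoro compound. The same change is large against the other two groups, with a number 32 percentage points lower from compound 2 to compound 4 (beyond the scatter) and, the largest step in the set, a number 51 percentage points lower from compound 3 to compound 4 (beyond the scatter), and this widens the spread of the series well beyond what the three earlier compounds showed. Nothing measured here bears on why methylsulfanyl lowers the number.

The compounds shown leave open whether the fall follows the sulfur or the added carbon, which a methoxy or an ethyl group at this place could separate. They also leave open whether any other group, such as bromo or an amine, would stand as high as chloro.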